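The compounds below may be only part of what the source reports. "The series", "measured", "known", "first", "only" and "open" are said of these compounds alone.

Measured compounds:
Compound 1, `CC(C)c1ccc(NC(=O)c2csc(Cc3c(Cl)cccc3Cl)n2)cc1`: 370 nM
Compound 2, `COc1ccc(NC(=O)c2csc(Cc3c(Cl)cccc3Cl)n2)cc1`: > 4000 nM

Both compounds share one core and differ only in the group carried on the amide-type nitrogen. In an assay on CHO cells, read by calcium flux (on this read-out higher numbers stand for weaker inhibition and lower numbers for stronger inhibition), compound 1 gives 370 nM. Going by these compounds, for compound 2 this assay returns no number but only a limit, > 4000 nM, so compound 2 stands at the limit of > 4000 nM in this assay, at which 1 of the 2 values shown sits, and its true value is unknown beyond that boundary. Among the compounds with values here, the one measured step, an at least 10-fold higher number from compound 1 to compound 2 (1.03 log units; beyond the scatter), shows that exchanging the group on this nitrogen can shift the read-out strongly.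

Compound 3, `O=C(Nc1ccc(Br)cn1)c1csc(Cc2c(Cl)cccc2Cl)n1`, has not yet been measured in this assay. Compared with compound 2 the change is 5-bromopyridin-2-yl in place of 4-methoxyphenyl on an amide-type nitrogen. Within the data shown here, no measured step covers this exact exchange; the step from compound 1 to compound 2 only shows that this position is sensitive. Because compound 2 sits at the limit of > 4000 nM in this assay, at which 1 of the 2 values shown sits, any move toward a stronger inhibitor would appear as a measurable number. Compound 3 is therefore expected to give 900 nM, within 150 nM to 4000 nM, an estimated step of an at least 4.4-fold lower number from compound 2 to compound 3 (0.64 log units; beyond the scatter).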

Compound 3, half-maximal inhibitory concentration: > 4000 nM
Compound 3: no number, only a limit; the forecaster's own chance of this, stated with the estimate: 30%; middle value at least 4.4-fold (0.64 log units) from the limit.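

In this assay compound 3 gives > 4000 nM, which is a limit and not a number. Within the data shown here, compound 2 also has only a limit there, so no step between compound 2 and compound 3 can be read. The compounds shown leave open whether 5-bromopyridin-2-yl or 4-methoxyphenyl gives the stronger inhibition.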